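Pyridin-2-yl ketone in place of the methoxyphenyl ketone

This account rests on a few compounds, and the source may have more. Where it says the series, first, only, none or still open, it means among the compounds named here.

Measured so far:
compound 1 `COc1ccc(C(=O)/C=C/c2nc3ccccc3cc2-c2ccc(OC)cc2)cc1`: 8500 nM
compound 2 `COc1ccc(-c2cc3ccccc3nc2/C=C/C(=O)c2ccc(OC)c(OC)c2)cc1`: 8860 nM

In a functional assay on A549 cells (Homo sapiens) for antiproliferative activity, read by XTT assay, with a stated time of 72 h (on this read-out higher numbers stand for weaker inhibition and lower numbers for stronger inhibition), compound 1 gives 8500 nM and compound 2 gives 8860 nM; the two lie within the scatter of each other, so compound 1 does not stand apart from compound 2. Within the data shown here, the only measured step, a 1.0-fold higher number from compound 1 to compound 2 (0.02 log units; within the scatter), puts a methoxy in place of hydrogen on an aromatic carbon and stays within the scatter.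

Compound 3 `COc1ccc(-c2cc3ccccc3nc2/C=C/C(=O)c2ccccn2)cc1` is not yet measured. It differs from compound 1 by pyridin-2-yl in place of 4-methoxyphenyl on a carbonyl carbon. Among the measured compounds shown here, no measured step touches the group on the carbonyl carbon; the one step known concerns a methoxy elsewhere and cannot be carried over. With nothing pointing in either direction, compared with compound 1 the expected step for compound 3 is small, a 1.1-fold higher number from compound 1 to compound 3 (0.02 log units; within the scatter), but the range must be wide. Compound 3 is therefore estimated at 9000 nM, between 3000 nM and 27000 nM.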

Compound 3, half-maximal inhibitory concentration: 6140 nM
Compound 3: middle estimate off by 1.5-fold (0.17 log units), on the high side; measured number inside the range.
By their numbers in this assay, from the lowest: compounds 3, 1 and 2 (each within the scatter of the next).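

In this assay the group on the carbonyl carbon can change from a carbon-only ring to a ring with a hetero atom and fewer heavy atoms while the number stays within the scatter: pyridin-2-yl in place of 4-methoxyphenyl gives a 1.4-fold lower number from compound 1 to compound 3 (0.14 log units; within the scatter) and pyridin-2-yl in place of 3,4-dimethoxyphenyl gives a 1.4-fold lower number from compound 2 to compound 3 (0.16 log units; within the scatter) on the same comparison. Until now only a methoxy on this ring had varied; here the whole ring is replaced, methoxy included, and the three numbers still sit together. No evidence is available on what lies behind this.

All groups shown on the carbonyl carbon are six-membered aromatic rings, so whether this position responds at all remains open. A methyl group, a piperidine ring or a phenyl ring bearing a carboxylic acid there would test it, as would pyridin-3-yl.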